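This account rests on a few compounds, and the source may have more. Where it says the series, first, only, none or still open, it means among the compounds named here.

Measured so far:
compound 1 `Fc1ccc(-c2nn(-c3ccccc3)cc2-c2nc3cc(F)ccc3[nH]2)cc1`: 1570 nM
compound 2 `Fc1ccc(-c2nn(-c3ccccc3)cc2-c2nc3cc(Cl)ccc3[nH]2)cc1`: 2770 nM
compound 3 `COc1ccc2[nH]c(-c3cn(-c4ccccc4)nc3-c3ccc(F)cc3)nc2c1`: 7510 nM

In a functional assay on HeLa cells (Homo sapiens) for antiproliferative activity, read by MTT assay, with a stated time of 48 h (on this read-out higher numbers stand for weaker inhibition and lower numbers for stronger inhibition), compound 2 gives 2770 nM, the second highest of the three numbers; compound 1 gives 1570 nM, within the scatter of it, and compound 3 lies beyond it, a 2.7-fold higher number from compound 2 to compound 3 (0.43 log units; beyond the scatter). Compound 4 `Clc1ccc(-c2nn(-c3ccccc3)cc2-c2nc3cc(Cl)ccc3[nH]2)cc1` is not yet measured. It differs from compound 2 by chloro in place of fluoro on an aromatic carbon, on an aromatic carbon of a six-membered aromatic ring of carbon only, para to a large group; cut one bond further out, 4-fluorophenyl to 4-chlorophenyl. Among the compounds with values here, the only measured step of the same kind, at a different aromatic carbon, is a 1.8-fold higher number from compound 1 to compound 2 (0.25 log units; within the scatter), and it stayed within the scatter. No step beyond the scatter is therefore expected in this assay. The expected step is a 1.1-fold higher number from compound 2 to compound 4 (0.03 log units; within the scatter). Compound 4 is estimated at 3000 nM, with a range of 1400 nM to 6500 nM.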

Compound 4, half-maximal inhibitory concentration: 1630 nM
Beside the measured number, compound 4's estimate is 1.8-fold (0.26 log units) above it; measured number inside the range.
By their numbers in this assay, from the lowest: compounds 1, 4 and 2 (each within the scatter of the next); then compound 3.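

Going from 4-fluorophenyl to 4-chlorophenyl gives a 1.7-fold lower number from compound 2 to compound 4 (0.23 log units; within the scatter) in this assay and so shows that chloro in place of fluoro at this position, para to a large group, produces no readable change. Together with a 1.8-fold higher number from compound 1 to compound 2 (0.25 log units; within the scatter) as the only other step of this kind, the same exchange now stays within the scatter at two different aromatic carbons. Nothing measured here accounts for the result.

Going by these compounds, whether an amine or a carboxylic acid on this aromatic carbon would move the number beyond the scatter remains open.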